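A few compounds are considered here, and "the series" means these few. Any claim that something is new, unique, unknown or untested is made for them only; others in the source may bear on it.

Measured so far in a functional assay on WM 266-4 cells (Homo sapiens) for antiproliferative activity, read by MTT assay, with a stated time of 24 h; a higher number here means a weaker inhibitor of growth, a lower number a stronger inhibitor of growth:
- compound 1 `c1ccc(N2N=C(c3ccc4c(c3)OCCO4)CC2c2cccc3ccccc23)cc1`: > 100000 nM, a limit of the assay
- compound 2 `c1ccc(N2N=C(c3ccc4c(c3)OCCO4)CC2c2ccco2)cc1`: > 100000 nM, a limit of the assay
- compound 3 `Fc1ccc(C2CC(c3ccc4c(c3)OCCO4)=NN2c2ccccc2)cc1`: 6050 nM

For the measured compounds named here, compound 3 is the only member of the trio with a number in this assay; the other two sit at the limit of > 100000 nM in this assay, at which 2 of the 3 values shown sit. Against those limits compound 3 shows an at least 16-fold lower number from compound 1 to compound 3 (1.21 log units; beyond the scatter) and an at least 16-fold lower number from compound 2 to compound 3 (1.21 log units; beyond the scatter), while between compound 1 and compound 2 the step is a step that the two limits leave unreadable from compound 1 to compound 2. All three measured steps vary the group on the saturated ring carbon.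

Compound 4 `c1ccc(COc2ccc(C3CC(c4ccc5c(c4)OCCO5)=NN3c3ccccc3)cc2)cc1` keeps that saturated-ring substituent and instead alters the 4-fluorophenyl: benzyloxy in place of fluoro on an aromatic carbon. Going by the values given here, no measured step touches this aromatic position, so none bears directly on it; the comparison rests on compound 3 alone, and the expected step is therefore set near zero, with wide uncertainty. The expected step is a 1.0-fold lower number from compound 3 to compound 4 (0.00 log units; within the scatter). Compound 4 is estimated at 6000 nM, with a range from 1500 nM to 30000 nM in this assay.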

Compound 4, concentration for 50% growth inhibition: 1130 nM
Compound 4: the middle estimate sits 5.3-fold (0.73 log units) above what was measured; measured number below the stated range.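

For the compounds shown here, the aromatic position para to a large group had no measured step until now, and in this assay benzyloxy in place of fluoro gives a 5.4-fold lower number from compound 3 to compound 4 (0.73 log units; beyond the scatter). The entering group brings 8 heavy atoms and one six-membered aromatic ring where fluoro has 1 heavy atom, so this position accepts a much larger group with no loss of growth inhibition in this pair. Nothing given here accounts for the step.

This single pair does not separate the contribution of the oxygen from that of the aromatic ring within benzyloxy. It also leaves open how a smaller methoxy group, a hydroxyl group or an amine at the same position would read in this assay.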